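Aryloxypropyl series: tert-butyl for methyl on compound 1

The compounds below may be only part of what the source reports. "The series", "measured", "known", "first", "only" and "open" are said of these compounds alone.

Compound 1 `Cc1ccc(OCCCON2C(N)=NC(N)=NC23CCOCC3)cc1` gives 1060 nM in a functional assay on A549 cells (Homo sapiens) for antiproliferative activity, read by MTT assay, with a stated time of 72 h (a higher number here means a weaker inhibitor, a lower number a stronger inhibitor), the highest number among the three measured compounds. Compound 2 `NC1=NC2(CCOCC2)N(OCCCOc2ccccc2Br)C(N)=N1` gives 160 nM in this assay, and compound 3 `NC1=NC2(CCOCC2)N(OCCCOc2ccc(Cl)cc2Cl)C(N)=N1` gives 70 nM. The measured steps away from compound 1 are a 6.6-fold lower number from compound 1 to compound 2 (0.82 log units; beyond the scatter) and a 15-fold lower number from compound 1 to compound 3 (1.18 log units; beyond the scatter); between the two halogenated analogues the step is a 2.3-fold lower number from compound 2 to compound 3 (0.36 log units; beyond the scatter).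

Compound 4 `CC(C)(C)c1ccc(OCCCON2C(N)=NC(N)=NC23CCOCC3)cc1` differs from compound 1 in one place: tert-butyl in place of methyl on an aromatic carbon. The change sits on an aromatic carbon of the six-membered carbon ring, para to a large group.

Among the compounds with values here, no measured step swaps one alkyl group for another at this position. The two steps from compound 1 each exchange the whole 4-methylphenyl for a halogen-bearing phenyl, and both lowered the number beyond the scatter, so substitution on this ring clearly registers in this assay. They say nothing directly about a larger alkyl group, and their direction cannot be carried over. The expected step is therefore a 1.4-fold lower number from compound 1 to compound 4 (0.15 log units; within the scatter), which is within or close to the scatter. Compound 4 is estimated at 750 nM in this assay, with a range from 250 nM to 2200 nM.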

Compound 4, half-maximal inhibitory concentration: 500 nM
Compound 4: middle estimate off by 1.5-fold (0.18 log units), on the high side; the range from low to high includes it.
By their numbers in this assay, from the lowest: compound 3; then compound 2; then compound 4; then compound 1.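

With the rest of the molecule held constant, tert-butyl in place of methyl on this aromatic carbon, para to a large group, gives a 2.1-fold lower number from compound 1 to compound 4 (0.33 log units; beyond the scatter) in this assay. Within the data shown here, this is the first measured step here that changes only the alkyl group, rather than exchanging the whole substituted phenyl. It shows that the position accepts a group of 4 heavy atoms in place of 1 heavy atom with no rise in the number, and that a purely alkyl change, with no halogen introduced, can produce a modest step beyond the scatter. No measurement on hand explains this step.

On these data alone, two alkyl groups fix only the end points of a single comparison, so it remains open whether ethyl or isopropyl at the same carbon would fall on a graded path between compound 1 and compound 4 or depart from it. Also open, as far as these compounds go, is how this position responds to groups containing heteroatoms, such as methoxy, an amine or a carboxylic acid, which would show whether the step extends beyond simple alkyl replacements.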